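The compounds below may be only part of what the source reports. "The series", "measured", "known", "first", "only" and "open" are said of these compounds alone.

Measured compounds:
compound 1, `CCOC(=O)CSc1nncc2cnc(C)n12`, 52000 nM in a functional assay for inhibition, with Homo sapiens as the target; on this read-out higher numbers stand for weaker inhibition and lower numbers for stronger inhibition
compound 2, `CCOC(=O)CSc1nncc2c(C)nc(C)n12`, > 48000 nM (a limit of this assay, not a number)
compound 3, `COCc1nc(C)c2cnnc(S)n12`, > 48000 nM (again a limit, not a number)

Compound 1 and compound 2 share a core and differ only by hydrogen in place of methyl on an aromatic carbon. The size of that step, a step that the limit leaves unreadable from compound 2 to compound 1, cannot be read because of the limit of > 48000 nM in this assay, at which 2 of the 3 values shown sit. The cores of compound 3 and compound 2 differ in more than one place, and that difference is not broken down here.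

Compound 4, `COCc1ncc2cnnc(S)n12`, is not yet measured. It arises from compound 3 by hydrogen in place of methyl on an aromatic carbon. This is the same kind of change as that from compound 2 to compound 1, though the surroundings differ: in compound 2 the ring atom two ring bonds away bears a methyl group, while in compound 3 it bears a methoxymethyl group.

In this assay, going by the values given here, the only measured instance of this change is unreadable, and compound 3 itself sits at a limit, so the expected step from compound 3 to compound 4 is small, a step that the limit leaves unreadable from compound 3 to compound 4. Compound 4 is therefore expected to give about 60000 nM, between 20000 nM and 200000 nM, most likely reported as a limit once more.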

Compound 4, half-maximal inhibitory concentration: > 48000 nM
Compound 4 gave a limit, no number; the forecaster's own chance of this, stated with the estimate: 70%; the middle value is on the limit's open side.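

Going by these compounds alone, compound 3 and compound 4 both give only a limit in this assay and not a number, so no step between them can be read, because of this: the limit of > 48000 nM in this assay, at which 3 of the 4 values shown sit.

The compounds shown leave open how strongly compound 2, compound 3 and compound 4 actually inhibit, and whether hydrogen in place of methyl changes inhibition in either pair.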